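Replacing a hydroxyphenyl with a pyrrole ring

This account rests on a few compounds, and the source may have more. Where it says the series, first, only, none or still open, it means among the compounds named here.

Compound 1 `CC1=CC[C@H](C(C)(C)NC(=S)N/N=C/c2ccccc2)CC1`: in a functional assay on UACC-62 cells (Homo sapiens) for inhibition, read by sulforhodamine B assay, with a stated time of 48 h (on this read-out lower numbers stand for stronger inhibition of growth and higher numbers for weaker inhibition of growth), compound 1 gives 31600 nM.
Compound 2 `CC1=CC[C@H](C(C)(C)NC(=S)N/N=C/c2ccc(O)cc2)CC1`: compound 2 gives only a limit, > 100000 nM.
Compound 3 `COc1cc(/C=N/NC(=S)NC(C)(C)[C@H]2CC=C(C)CC2)ccc1O`: compound 3 gives 14700 nM.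

Compound 2 thus stands at the weak end of the three, known only as a limit. Compound 4 `CC1=CC[C@H](C(C)(C)NC(=S)N/N=C/c2ccc[nH]2)CC1` differs from it by 1H-pyrrol-2-yl in place of 4-hydroxyphenyl on a carbon with a double bond to nitrogen. Going by the values given here, two measured steps touch compound 2: an at least 3.1-fold higher number from compound 1 to compound 2 (0.50 log units; beyond the scatter) and an at least 6.8-fold lower number from compound 2 to compound 3 (0.83 log units; beyond the scatter); both rest on (the limit of > 100000 nM in this assay, at which 1 of the 3 values shown sits), so their true size is uncertain. Removing the hydroxyphenyl should bring the number back toward a measurable value, and for compound 4 a step of an at least 3.3-fold lower number from compound 2 to compound 4 (0.52 log units; beyond the scatter) is expected. Compound 4 is estimated at 30000 nM, ranging from 10000 nM to 100000 nM.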

Compound 4, concentration for 50% growth inhibition: 14800 nM
Beside the measured number, compound 4's estimate is 2.0-fold (0.31 log units) above it, within the range that was stated.
By their numbers in this assay, from the lowest: compounds 3 and 4 (each within the scatter of the next); then compound 1. At a limit, above all of these: compound 2.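

At this carbon with a double bond to nitrogen, a five-membered aromatic ring with 1 hetero atom can take the place of a six-membered one. Putting 1H-pyrrol-2-yl in place of phenyl gives a 2.1-fold lower number from compound 1 to compound 4 (0.33 log units; beyond the scatter), and putting it in place of 4-hydroxyphenyl gives an at least 6.7-fold lower number from compound 2 to compound 4 (0.82 log units; beyond the scatter). Compound 2 is known only as a limit, so the size of that second step is uncertain: the limit of > 100000 nM in this assay, at which 1 of the 4 values shown sits.

Going by these compounds, whether other five-membered rings, such as furan or thiophene, would behave like pyrrole remains open. So does the effect of a methyl group on the pyrrole nitrogen.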